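The source may hold more compounds than are shown below. What is called first, only, known or untested is meant among the compounds shown, and "the series" means these compounds.

Compound 1 `Nc1ccc(C(=O)/C=C/c2ccc(Cl)cc2)cc1`, compound 2 `Nc1ccc(C(=O)/C=C/c2ccco2)cc1` and compound 3 `O=C(CBr)Nc1ccc(C(=O)/C=C/c2ccc(Cl)cc2)cc1` share a core and were all measured in a functional assay on the whole organism (strain albino) for inhibition, with Rattus norvegicus as the target, read by paw edema, with stated times of 30 min and 4 h, at a dose of 100 mg/kg by the oral route; on this read-out lower numbers stand for less inhibition and higher numbers for more inhibition at the one dose given (going by the name of the read-out). In this assay compound 1 gives 58%, compound 2 gives 33% and compound 3 gives 59%. Among the three numbers that of compound 3 stands highest, although it and the value of compound 1 lie within the scatter of each other, while the gap between compound 3 and compound 2 lies beyond it. Within the data shown here, the only step between measured compounds that differ in one place is a number 1 percentage points higher from compound 1 to compound 3 (within the scatter). Compound 4 `COc1ccc(/C=C/C(=O)c2ccc(NC(=O)CBr)cc2)cc1` differs from compound 3 by methoxy in place of chloro on an aromatic carbon. Among the measured compounds shown here, no measured step alters this part of the six-membered aromatic ring of carbon only, and the measured step, which concerns the nitrogen on the other ring, does not bear on it; compound 2 carries a different ring altogether and is not a one-place comparison. Compound 4 is therefore expected to give 52% in this assay, with a range from 35% to 68%, and the step of a number 7 percentage points lower from compound 3 to compound 4 (within the scatter) is expected to stay within the scatter.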

Compound 4, a percentage reported as inhibition, in the whole organism at one dose (the size of the read-out at that dose, not a potency): 41%
For compound 4 the middle estimate is 11 percentage points above the measured one, within the range that was stated.
By their numbers in this assay, from the lowest: compounds 2 and 4 (each within the scatter of the next); then compounds 1 and 3 (each within the scatter of the next).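

In this assay, methoxy in place of chloro on an aromatic carbon, para to a large group, gives a number 18 percentage points lower from compound 3 to compound 4 (beyond the scatter) and so registers beyond the scatter. The only earlier one-place step, at the nitrogen on the other ring, was a number 1 percentage points higher from compound 1 to compound 3 (within the scatter), so this is the first sign among these compounds that a single change can shift the read-out, and it shows that this position is sensitive to the group it carries, at least with the (bromomethyl)carbonyl group on the nitrogen. Nothing shown here accounts for the loss of inhibition, and its cause remains unknown.

From the compounds shown here alone, it remains open whether a hydroxy, fluoro or dimethylamino group at this position would stay close to chloro or fall towards methoxy. Going by these compounds, it is equally open whether the same exchange would give a similar step with the free amine on the other ring.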